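This account rests on a few compounds, and the source may have more. Where it says the series, first, only, none or still open, it means among the compounds named here.

Compound 1 `CS(=O)(=O)c1ccc(-c2nc3ccccn3c2Sc2ccccc2)cc1`: 72700 nM
Compound 2 `Cc1ccc2nc(-c3ccc(Cl)cc3)c(Sc3ccccc3)n2c1`: 94500 nM

In a functional assay on MDA-MB-231 cells (Homo sapiens) for inhibition, read by MTT assay, with a stated time of 48 h (on this read-out lower numbers stand for stronger inhibition and higher numbers for weaker inhibition), compound 2 at 94500 nM cannot be told apart from compound 1, since the two values lie within the usual scatter. Compound 3 `Clc1ccc(-c2nc3ccccn3c2Sc2ccccc2)cc1` differs from compound 2 in one place: hydrogen in place of methyl on an aromatic carbon. Among the compounds with values here, no measured pair shows this change, so the expectation is cautious: no step beyond the scatter in this assay, and no clear direction. The expected change is a 1.2-fold lower number from compound 2 to compound 3 (0.07 log units; within the scatter). For compound 3 the estimated value is 80000 nM, with an expected range from 35000 nM to 170000 nM.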

Compound 3, half-maximal inhibitory concentration: 24500 nM
For compound 3 the middle estimate is 3.3-fold (0.51 log units) above the measured one, outside the stated range (below it).
By their numbers in this assay, from the lowest: compound 3; then compounds 1 and 2 (each within the scatter of the next).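

Taking away the methyl, which sits on a carbon two atoms from the ring nitrogen, is not a neutral change: this assay gives a 3.9-fold lower number from compound 2 to compound 3 (0.59 log units; beyond the scatter) and so shows that this position responds to what it carries. With hydrogen at that position, the other site also matters, as chloro in place of methylsulfonyl gives a 3.0-fold lower number from compound 1 to compound 3 (0.47 log units; beyond the scatter). No supporting measurement explains either step. From the compounds shown here alone, whether an amine or a methoxy group at the methyl position would match hydrogen remains open. So does how a carboxylic acid would compare with chloro.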